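This account rests on a few compounds, and the source may have more. Where it says the series, first, only, none or still open, it means among the compounds named here.

Measured so far in a functional assay on KBVIN cells (Homo sapiens) for antiproliferative activity, read by sulforhodamine B assay, with a stated time of 3 days; on this read-out higher numbers stand for an effect only at larger amounts of compound and lower numbers for an effect already at smaller amounts:
Compound 1 `CCCc1ccc(-c2cc(=O)c3c(o2)C(CC)(CC)C(=O)C(CC)=C3O)cc1`: 12.2 uM
Compound 2 `CCC1=C(O)c2c(oc(-c3ccc(CC(C)C)cc3)cc2=O)C(CC)(CC)C1=O`: 17.4 uM
Compound 3 `CCC1=C(O)c2c(oc(-c3ccc(OC)cc3)cc2=O)C(CC)(CC)C1=O`: 0.68 uM

Compound 4 `CCOc1ccc(-c2cc(=O)c3c(o2)C(CC)(CC)C(=O)C(CC)=C3O)cc1` has not yet been measured. It arises from compound 3 by methyl in place of hydrogen on a saturated chain carbon bound to an oxygen on an aromatic ring. The same kind of change links two measured compounds: compound 2 arises from compound 1 by methyl in place of hydrogen on a saturated chain carbon bound to two saturated chain carbons, and that step gave a 1.4-fold higher number from compound 1 to compound 2 (0.15 log units; within the scatter). The two changes are of the same kind, not the same: in the first the new methyl sits on a saturated chain carbon bound to two saturated chain carbons, in the second on a saturated chain carbon bound to an oxygen on an aromatic ring. The cores also differ, by methoxy in place of propyl on an aromatic carbon, a change that went with an 18-fold lower number from compound 1 to compound 3 (1.25 log units; beyond the scatter) and, from compound 2, with a 26-fold lower number from compound 2 to compound 3 (1.41 log units; beyond the scatter).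

Because the measured example of this kind of change gave a 1.4-fold higher number from compound 1 to compound 2 (0.15 log units; within the scatter), the step from compound 3 to compound 4 in this assay is expected to be small as well, about a 1.3-fold higher number from compound 3 to compound 4 (0.12 log units; within the scatter). Compound 4 is therefore estimated to give about 0.9 uM, most likely between 0.3 uM and 2.5 uM.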

Compound 4, concentration for half-maximal effect: 7.54 uM
For compound 4 the middle estimate is 8.4-fold (0.92 log units) below the measured one, and the stated range ends below it.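

In this assay, the new methyl gave an 11-fold higher number from compound 3 to compound 4 (1.04 log units; beyond the scatter), and this step does not match the earlier one: the same change on two cores in this assay, a 1.4-fold higher number (0.15 log units; within the scatter) from compound 1 to compound 2 and an 11-fold higher number (1.04 log units; beyond the scatter) from compound 3 to compound 4, 7.8-fold (0.89 log units) apart, beyond the scatter of two such steps. Ethoxy in compound 4 compares with the larger groups as follows: ethoxy in place of propyl gave a 1.6-fold lower number from compound 1 to compound 4 (0.21 log units; within the scatter), and ethoxy in place of isobutyl gave a 2.3-fold lower number from compound 2 to compound 4 (0.36 log units; beyond the scatter), so among these four compounds only compound 3 stands well apart. This shows that a small step seen with this kind of change on one core cannot be assumed to hold on another, but with just two pairs, and with the new methyl in a different place in each, it cannot tell whether the core or the place accounts for the gap, and it sets no general rule for the series.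

As far as these compounds go, it remains open how a longer ether chain such as propoxy would fare on that aromatic carbon. An amine or a carboxylic acid there is also an open question.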